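The source may report more compounds than this note shows. Statements on the series, on what has been measured and on what is new or still open speak of the compounds shown alone.

Of the compounds shown here, three sharing one core have been measured in a functional assay on PC-12 cells (Rattus norvegicus) for cytotoxicity, read by MTT assay, with stated times of 2 h and 24 h, tested at 5 uM; a higher number here means a stronger effect of the compound at the concentration tested, a lower number a weaker effect. Compound 1, `CC(C)(C)c1ccc(-n2nc(-c3ccc(C(F)(F)F)cc3O)nc2-c2ccccc2O)cc1`, gives 77.8%. Compound 2, `COc1ccc(-n2nc(-c3ccc(C(F)(F)F)cc3O)nc2-c2ccccc2O)cc1`, gives 86.6%. Compound 3, `Oc1cc(C(F)(F)F)ccc1-c1nc(-c2ccccc2O)n(-c2ccccc2Cl)n1`, gives 90.6%, the largest of the three numbers; its gap to compound 2 lies within the scatter, while its gap to compound 1 lies beyond it.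

The unmeasured compound 4 is `Oc1cc(C(F)(F)F)ccc1-c1nc(-c2ccccc2O)n(-c2ccc(F)cc2F)n1`. Against compound 3 the change is 2,4-difluorophenyl in place of 2-chlorophenyl on an aromatic nitrogen. The group that sits on this aromatic nitrogen has been varied twice among the measured compounds. The step of a number 12.8 percentage points higher from compound 1 to compound 3 (beyond the scatter) is the only one beyond the scatter, and it is modest. The step of a number 4 percentage points higher from compound 2 to compound 3 (within the scatter) and the step of a number 8.8 percentage points higher from compound 1 to compound 2 (within the scatter) both stay within the scatter. So swapping the group on this nitrogen has so far moved the number in this assay by little, and compound 3 already sits near the top of the measured range. For compound 4 the expected shift is therefore a number 2.6 percentage points lower from compound 3 to compound 4 (within the scatter), that is, none clearly beyond the scatter. The estimate for compound 4 in this assay is 88%, with a likely range from 76% to 97%.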

Compound 4, a percentage reported as activity, at one concentration (the size of the read-out at that concentration, not a potency): 83.5%
Compound 4: the middle estimate sits 4.5 percentage points above what was measured, within the range that was stated.
By their numbers in this assay, from the lowest: compounds 1, 4, 2 and 3 (each within the scatter of the next, the first and the last beyond it).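

Among these compounds, the fourth group on this aromatic nitrogen is the first to carry two halogen atoms, and in this assay the swap gives a number 7.1 percentage points lower from compound 3 to compound 4 (within the scatter) and, against the other two groups, a number 3.1 percentage points lower from compound 2 to compound 4 (within the scatter) and a number 5.7 percentage points higher from compound 1 to compound 4 (within the scatter). Among the compounds shown here, none of these three new steps leaves the scatter, so 2,4-difluorophenyl cannot be told apart from 2-chlorophenyl, 4-methoxyphenyl or 4-(tert-butyl)phenyl here, and the step from compound 1 to compound 3 remains the only one among the four compounds that lies beyond it. No measurement of any other kind accompanies these numbers, so nothing here accounts for the differences between the groups at this position.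

As far as these compounds go, all four groups on this nitrogen are substituted phenyl rings, so it remains open how this assay would respond to something of another kind there, such as a benzyl group, a short alkyl chain or a phenyl ring bearing a carboxylic acid. From the compounds shown here alone, the trifluoromethyl group and both hydroxy groups are the same in all four compounds, so what an amine in place of either hydroxy group would do also remains open.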